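A few compounds are considered here, and "the series" means these few. Any claim that something is new, unique, unknown or untested is made for them only; others in the source may bear on it.

Measured compounds:
- compound 1, `CCCCNc1nc(N)nnc1OCc1ccccc1F`, in an assay on isolated protein for agonist activity at Toll-like receptor 8 (Homo sapiens) (on this read-out lower numbers stand for an effect already at smaller amounts and higher numbers for an effect only at larger amounts of compound), gives 560 nM
- compound 2, `CCCCNc1nc(N)nnc1OC`, gives 2040 nM
- compound 3, `CCCCNc1nc(N)nnc1OCc1ccccc1OC`, gives 640 nM

All three share one core and differ only in the group attached to its ring oxygen. Among the three, compound 3 stands second highest: its number lies within the scatter of compound 1 and is set apart only from compound 2, whose higher number lies beyond the scatter.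

Compound 4, `CCCCNc1nc(N)nnc1OCc1ccccc1`, is not yet measured. It differs from compound 3 in one place: hydrogen in place of methoxy on an aromatic carbon. Going by the values given here, two measured steps bear on this. The step of a 3.6-fold higher number from compound 1 to compound 2 (0.56 log units; beyond the scatter) shows that taking away the whole benzyl-type group costs a modest amount of potency. The step of a 1.1-fold higher number from compound 1 to compound 3 (0.06 log units; within the scatter) shows that exchanging one small substituent on that ring for another makes no difference beyond the scatter. Compound 4 keeps the ring and loses only the small substituent, so the second step is the closer guide.

On that basis compound 4 is expected to give 620 nM in this assay, with a likely range from 300 nM to 1300 nM, a step of a 1.0-fold lower number from compound 3 to compound 4 (0.01 log units; within the scatter) that is expected to stay within the scatter.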

Compound 4, half-maximal effective concentration: 1930 nM
The estimate for compound 4 lay 3.1-fold (0.49 log units) below the measured number, and the stated range ends below it.
By their numbers in this assay, from the lowest: compounds 1 and 3 (each within the scatter of the next); then compounds 4 and 2 (each within the scatter of the next).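

In this assay, the small substituent on the aromatic ring turns out to matter at this place, on an aromatic carbon ortho to a large group: hydrogen in place of methoxy gives a 3.0-fold higher number from compound 3 to compound 4 (0.48 log units; beyond the scatter), and hydrogen in place of fluoro gives a 3.4-fold higher number from compound 1 to compound 4 (0.54 log units; beyond the scatter). The ring alone brings no benefit, since phenyl in place of hydrogen on the chain carbon gives only a 1.1-fold lower number from compound 2 to compound 4 (0.02 log units; within the scatter), which lies within the scatter, so the earlier loss on removing the whole 2-fluorophenyl group cannot be credited to the ring by itself; in this small set, the ring gives the lower numbers only when it carries fluoro or methoxy, two different groups whose compounds stay within the scatter of each other. No measurement shown here explains why either group has this effect.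

The compounds shown leave open whether a chlorine, a methyl group or an amine at this place would act like fluoro and methoxy. They also leave open whether fluoro or methoxy would do the same on another carbon of the ring, or whether the effect would persist with a longer chain in place of butyl.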